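The compounds below may be only part of what the source reports. "The series", "measured", "known", "first", "only" and "open" are said of these compounds alone.

Measured so far:
compound 1 `O=C(Nc1ccc(Oc2ccnc3[nH]ccc23)cc1)c1cn(-c2ccc(Br)cc2F)c2ccccc2c1=O`: 790 nM
compound 3 `Cn1ccc2c(Oc3ccc(NC(=O)c4cn(-c5ccc(Br)cc5)c5ccccc5c4=O)cc3F)ccnc21`: 1260 nM
compound 2 `O=C(Nc1ccc(Oc2ccnc3[nH]ccc23)cc1)c1cn(-c2ccc(C(F)(F)F)cc2Cl)c2ccccc2c1=O`: "not determined" (no result reported)

In a functional assay on HepG2 cells (Homo sapiens) for inhibition, read by MTT assay, with a stated time of 72 h (a lower number here means a stronger inhibitor, a higher number a weaker inhibitor), compound 1 gives 790 nM. Compound 3 gives 1260 nM in this assay, the higher of the two numbers, but the gap to compound 1 lies within the scatter, so no order between them is read. No step between measured compounds is shown, and compound 2 contributes no number.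

Compound 4 `COc1ccc(-n2cc(C(=O)Nc3ccc(Oc4ccnc5c4ccn5C)c(F)c3)c(=O)c3ccccc32)cc1` differs from compound 3 by methoxy in place of bromo on an aromatic carbon; the same difference, cut one bond further out, reads: 4-bromophenyl to 4-methoxyphenyl, on an aromatic carbon para to a large group. Within the data shown here, with no measured step to lean on, the expected change from compound 3 to compound 4 is a 1.2-fold higher number from compound 3 to compound 4 (0.08 log units; within the scatter), that is, nothing beyond the scatter. Compound 4 is therefore estimated at 1500 nM, within 500 nM to 4500 nM.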

Compound 4, half-maximal inhibitory concentration: 3750 nM
Estimate against measurement, compound 4: 2.5-fold (0.40 log units) below; the measured number falls inside the stated range.
By their numbers in this assay, from the lowest: compounds 1 and 3 (each within the scatter of the next); then compound 4.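

In this assay, among these compounds, the change from 4-bromophenyl to 4-methoxyphenyl gives a 3.0-fold higher number from compound 3 to compound 4 (0.47 log units; beyond the scatter) and is the first one-place step to lie beyond the scatter. The aromatic carbon para to a large group is therefore not indifferent to what it carries: here, methoxy goes with the weaker inhibitor. As far as these compounds go, whether an amine or a carboxylic acid at this place would track with bromo or with methoxy remains open, as does whether the step holds on another core. Nothing measured here accounts for the step.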